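Trading a substituted pyrazolyl for a difluoropiperidinyl on the amide arm

This account rests on a few compounds, and the source may have more. Where it says the series, first, only, none or still open, it means among the compounds named here.

Of the two measured compounds, compound 1 `Cc1nn(CC(=O)N2CCN(c3sc(C(F)(F)F)nc3-c3nc4ccccc4[nH]3)C[C@H]2C)cc1CN(C)C` holds the lower number in a functional assay on Venous blood for antagonist activity at C-X-C chemokine receptor type 3 (Homo sapiens), read by flow cytometry, with a stated time of 30 min, in the presence of a further agent that is not named here; a higher number here means a weaker inhibitor, a lower number a stronger inhibitor: compound 1 gives 330 nM. Compound 2 `Cc1nc(C)n(CC(=O)N2CCN(c3sc(C(F)(F)F)nc3-c3nc4c(C(F)(F)F)cccc4[nH]3)C[C@H]2C)n1` differs from it in more than one place and in this assay gives 747 nM, a gap beyond the usual scatter. Among the measured compounds shown here, no pair of measured compounds differs in a single place, so no step can be read off directly.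

Compound 3 `C[C@@H]1CN(c2sc(C(F)(F)F)nc2-c2nc3ccccc3[nH]2)CCN1C(=O)CN1CCC(F)(F)CC1` differs from compound 1 in one place: 4,4-difluoropiperidin-1-yl in place of 4-((dimethylamino)methyl)-3-methyl-1H-pyrazol-1-yl on a saturated chain carbon bound to a carbonyl carbon. The data hold no comparable change, so a modest weakening is expected as the step of a 1.8-fold higher number from compound 1 to compound 3 (0.26 log units; within the scatter). In this assay compound 3 is expected to give about 600 nM, estimated between 250 nM and 1500 nM.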

Compound 3, half-maximal inhibitory concentration: 2430 nM
Compound 3: middle estimate off by 4.1-fold (0.61 log units), on the low side, outside the stated range (above it).
By their numbers in this assay, from the lowest: compound 1; then compound 2; then compound 3.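

At the saturated chain carbon bound to a carbonyl carbon, 4,4-difluoropiperidin-1-yl in place of 4-((dimethylamino)methyl)-3-methyl-1H-pyrazol-1-yl gives a 7.4-fold higher number from compound 1 to compound 3 (0.87 log units; beyond the scatter) in this assay and so lies beyond the usual scatter. This first single-place comparison shows that the group at this position cannot be exchanged freely on the core of compound 1. Nothing measured here accounts for the size of the step. The compounds shown leave open whether the dimethylaminomethyl arm or the pyrazole ring matters more. A 4-(dimethylamino)piperidin-1-yl group or a plain 3-methyl-1H-pyrazol-1-yl group would separate the two.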